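Two purine-type cores and one swap of a ring substituent

The source may hold more compounds than are shown below. What is called first, only, known or untested is meant among the compounds shown, and "the series" means these compounds.

The measurements come from an ADME assay on L1210/0 cells (Mus musculus) for cytotoxicity, with a stated time of 48 h; on this read-out higher numbers stand for weaker inhibition and lower numbers for stronger inhibition. Compound 1 `Nc1ncnc2c1ncn2C[C@@H]1CCC[C@H]1CO` carries a core that is not shared with the two compounds that follow. In this assay compound 1 gives > 200000 nM, which is a limit of the assay rather than a number. Compound 2 `Nc1nc2c(nc(N)n2COCCO)c(=O)[nH]1` is built on a different core. In this assay compound 2 gives > 200000 nM, again a limit. Compound 3 `Nc1nc2c(nc(O)n2COCCO)c(=O)[nH]1` differs from compound 2 in one place, by hydroxy in place of amino on an aromatic carbon. In this assay compound 3 gives > 200000 nM, also a limit. The resulting step is a step that the two limits leave unreadable from compound 2 to compound 3; it cannot be read, because of the limit of > 200000 nM in this assay, at which 3 of the 3 values shown sit. How the core of compound 1 differs from the core of compound 2 is not broken down here.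

Compound 4 `OC[C@@H]1CCC[C@H]1Cn1cnc2c(O)ncnc21` is not yet measured. It differs from compound 1 by hydroxy in place of amino on an aromatic carbon. Going by the values given here, this is the same kind of change as the one from compound 2 to compound 3, but the surroundings differ: in compound 3 the swapped carbon sits in a five-membered aromatic ring with two nitrogen atoms, between two ring nitrogen atoms and next to the ring atom that bears a (2-hydroxyethoxy)methyl group, whereas in compound 4 it sits in a six-membered aromatic ring with two nitrogen atoms, next to the ring nitrogen, ortho and meta to a fused ring. Since the measured step lands on a limit at both ends and compound 1 itself gives only a limit, the step from compound 1 to compound 4 is expected to be a step that the limit leaves unreadable from compound 1 to compound 4. Compound 4 is therefore estimated at 300000 nM, between 100000 nM and 1000000 nM, with the assay most likely reporting only a limit again.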

Compound 4, half-maximal inhibitory concentration: > 200000 nM
Compound 4 ended at the assay's limit (the forecaster's own chance of this, stated with the estimate: 85%); the middle value does not contradict the limit.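

Going by these compounds alone, compound 1 and compound 4 both end at a limit of the assay rather than at a number, so in this assay the change from amino to hydroxy between them gives no step that can be read: (the limit of > 200000 nM in this assay, at which 4 of the 4 values shown sit). The compounds shown leave open whether hydroxy in place of amino on an aromatic carbon changes the result in this assay at all, on either core.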